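Adding a 3-Acetylphenyl Group to a Benzoxaborole Amide

The compounds below may be only part of what the source reports. "The series", "measured", "known", "first", "only" and "open" are said of these compounds alone.

This series shares one core, a cyclic boron-containing bicycle joined through a short chain to an amide of an aniline, and is tested in a functional assay on HCT-116 cells (Homo sapiens) for antiproliferative activity, read by MTT assay, with a stated time of 72 h; a higher number here means a weaker inhibitor, a lower number a stronger inhibitor. Compound 1 `O=C(CCc1cccc2c1B(O)OC2)Nc1ccccc1` carries no substituent on the aniline ring and in this assay gives 350 nM, the lowest of the two plain numbers seen so far. Compound 2 `COc1ccc(NC(=O)CCc2cccc3c2B(O)OC3)cc1` gives 1700 nM. Compound 3 `CCOC(=O)c1ccc(NC(=O)CCc2cccc3c2B(O)OC3)cc1` reaches only the limit of this assay, > 100000 nM, so it is a limit rather than a number; that is the point recorded in the limit of > 100000 nM in this assay, at which 1 of the 3 values shown sits.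

The two steps that can be read show that a 4.9-fold higher number from compound 1 to compound 2 (0.69 log units; beyond the scatter) and that an at least 280-fold higher number from compound 1 to compound 3 (2.45 log units; beyond the scatter); both substitutions of the aniline ring made the inhibitor weaker, the second far more than the first.

Compound 4 `CC(=O)c1cccc(-c2cccc(NC(=O)CCc3cccc4c3B(O)OC4)c2)c1` is not yet measured. It differs from compound 1 in this way: 3-acetylphenyl in place of hydrogen on an aromatic carbon. Among the compounds with values here, no measured step puts a group at this position, and the new group is much larger than either of those tested, so the earlier steps bear on it only loosely. A weaker inhibitor than compound 1 is still the likelier outcome, and for compound 4 the expected step is a 7.1-fold higher number from compound 1 to compound 4 (0.85 log units; beyond the scatter), which is an estimate. In this assay compound 4 is therefore expected to give about 2500 nM, plausibly between 400 nM and 25000 nM.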

Compound 4, half-maximal inhibitory concentration: 86 nM
Compound 4: the middle estimate sits 29-fold (1.46 log units) above what was measured; the measured number lies below the stated range.
By their numbers in this assay, from the lowest: compound 4; then compound 1; then compound 2. At a limit, above all of these: compound 3.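

In this assay, 3-acetylphenyl on an aromatic carbon meta to a large group brings a 4.1-fold lower number from compound 1 to compound 4 (0.61 log units; beyond the scatter) and so makes compound 4 a stronger inhibitor than the unsubstituted compound 1. The earlier changes to the aniline ring, methoxy in compound 2 and ethoxycarbonyl in compound 3, both gave a weaker inhibitor, so this is the only substitution shown that moves the number down, and it shows that a group carrying a whole extra aromatic ring can be accepted at this position. The data shown offer no measurement that explains this gain in antiproliferative activity.

The compounds shown leave open whether the gain comes from the added ring or from its acetyl group; a plain phenyl at this position, or an amine or a carboxylic acid in place of the acetyl, would separate the two. They also leave open how much of the difference from compound 2 and compound 3 lies in the position on the ring and how much in the group itself, which methoxy or ethoxycarbonyl at this same position would help to settle.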